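A few compounds are considered here, and "the series" means these few. Any claim that something is new, unique, unknown or untested is made for them only; others in the source may bear on it.

Measured so far:
Compound 1, `Cc1ccc(-n2cc(CNC(=O)c3cccc4c3cnn4C(C)C)nn2)cc1`. In a functional assay on MGC-803 cells (Homo sapiens) for inhibition, read by MTT assay, with a stated time of 72 h (a lower number here means a stronger inhibitor, a higher number a weaker inhibitor), compound 1 gives only a limit, > 40000 nM.
Compound 2, `CC(C)n1ncc2c(C(=O)NCc3cn(Cc4ccccc4)nn3)cccc21`. In this assay compound 2 gives 14300 nM.

Going by the values given here, compound 2 holds the only numeric value in this assay; the other result is a limit, as described by the limit of > 40000 nM in this assay, at which 1 of the 2 values shown sits. Among the compounds with values here, the single measured step, an at least 2.7-fold lower number from compound 1 to compound 2 (0.44 log units; beyond the scatter), swaps the group on the triazole nitrogen.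

Compound 3, `COc1ccc(Cn2cc(CNC(=O)c3cccc4c3cnn4C(C)C)nn2)cc1`, differs from compound 2 by methoxy in place of hydrogen on an aromatic carbon. Within the data shown here, no measured step concerns a methoxy group, so the change has no direct precedent here; the one step on record, an at least 2.7-fold lower number from compound 1 to compound 2 (0.44 log units; beyond the scatter), alters a different part of the same substituent and gives no guidance on adding methoxy. Compound 3 is therefore expected to stay within the scatter of compound 2, a step of a 1.2-fold lower number from compound 2 to compound 3 (0.08 log units; within the scatter). Compound 3 is estimated at 12000 nM in this assay, with a range from 4000 nM to 40000 nM.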

Compound 3, half-maximal inhibitory concentration: > 40000 nM
Compound 3 gave a limit, no number; the forecaster's own chance of this, stated with the estimate: 20%; middle value at least 3.3-fold (0.52 log units) away from the limit.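

Moving from benzyl to 4-methoxybenzyl weakens the compound in this assay, with an at least 2.7-fold higher number from compound 2 to compound 3 (0.44 log units; beyond the scatter). The earlier step showed that the group on the triazole nitrogen matters; this one shows that a single methoxy on the aromatic ring of the benzyl group, para to a large group, is also enough to change the result beyond the scatter. Compound 1 and compound 3 both end at a limit, so the step between them cannot be read, and compound 2 remains the only compound with a number: the limit of > 40000 nM in this assay, at which 2 of the 3 values shown sit.

On these data alone, whether fluorine, a hydroxyl or a methyl at that same place would keep the activity of compound 2 stays open, as does the effect of a methoxy elsewhere on the ring. As far as these compounds go, how far compound 3 really lies from compound 2 is also open, since the step gives only a bound.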